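The source may hold more compounds than are shown below. What is called first, only, known or untested is meant among the compounds shown, and "the series" means these compounds.

For the measured compounds named here, compound 1 `COc1ccc(/C=C/c2cc(OC)cc(OC)c2/C=C/C(=O)c2cccc(OC)c2)cc1` gives 11.6 ug/mL in a functional assay on HepG2 cells (Homo sapiens) for antiproliferative activity, read by MTT assay, with a stated time of 48 h (on this read-out higher numbers stand for weaker inhibition and lower numbers for stronger inhibition), the lowest of the two numbers measured so far, with compound 2 `COc1ccc(/C=C/c2cc(OC)cc(OC)c2/C=C/C(=O)c2ccc(C(F)(F)F)cc2)cc1` nearest at 18.7 ug/mL. Going by the values given here, the only measured step, a 1.6-fold higher number from compound 1 to compound 2 (0.21 log units; within the scatter), exchanges the aryl on the carbonyl carbon. Compound 3 `COc1ccc(/C=C/c2cc(OC)cc(OC)c2/C=C/C(=O)c2ccccc2)cc1` differs from compound 1 by hydrogen in place of methoxy on an aromatic carbon, again on that carbonyl aryl. Among the compounds with values here, since the one comparable change gave nothing beyond the scatter, no step beyond the scatter is expected in this assay for compound 3. Compound 3 is therefore estimated at 12 ug/mL, within a range of 5 ug/mL to 30 ug/mL. The expected step is a 1.0-fold higher number from compound 1 to compound 3 (0.01 log units; within the scatter).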

Compound 3, half-maximal inhibitory concentration: 6.8 ug/mL
Compound 3: middle estimate off by 1.8-fold (0.25 log units), on the high side, within the range that was stated.
By their numbers in this assay, from the lowest: compounds 3, 1 and 2 (each within the scatter of the next, the first and the last beyond it).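

Hydrogen in place of methoxy on the carbonyl aryl stays within the scatter (a 1.7-fold lower number from compound 1 to compound 3 (0.23 log units; within the scatter)). Hydrogen in place of trifluoromethyl gives the first step beyond the scatter at this aryl (a 2.8-fold lower number from compound 2 to compound 3 (0.44 log units; beyond the scatter)), so this aryl is not indifferent to what it carries, and the plain phenyl gives up nothing against either substituted compound. Nothing at hand explains why the two replacements differ. Open, from the compounds shown here alone, is how an amine or a carboxylic acid on that phenyl would compare with hydrogen.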